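From 3-methoxyphenyl to 3-nitrophenyl

The source may hold more compounds than are shown below. What is called first, only, known or untested is meant among the compounds shown, and "the series" means these compounds.

Within the data shown here, in a functional assay on SK-BR-3 cells (Homo sapiens) for antiproliferative activity, read by CCK-8 assay, with a stated time of 72 h (on this read-out lower numbers stand for stronger inhibition and higher numbers for weaker inhibition), compound 3 (`COc1cccc(Nc2nc(Nc3cc(C)[nH]n3)cc(N3CCN(C)CC3)n2)c1`) gives 11300 nM, the highest of the three numbers so far. Compound 2 (`Cc1cc(Nc2cc(N3CCN(C)CC3)nc(Nc3ccc(Cl)cc3)n2)n[nH]1`) gives 1610 nM, and compound 1 (`Cc1cc(Nc2cc(N3CCN(C)CC3)nc(Nc3ccc([N+](=O)[O-])cc3)n2)n[nH]1`) gives 437 nM. Compound 4 (`Cc1cc(Nc2cc(N3CCN(C)CC3)nc(Nc3cccc([N+](=O)[O-])c3)n2)n[nH]1`) remains unmeasured. It carries nitro in place of methoxy on an aromatic carbon, meta to a large group: nitro in place of methoxy on an aromatic carbon.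

Among the measured compounds shown here, no measured pair makes exactly this exchange. The closest evidence is a 26-fold higher number from compound 1 to compound 3 (1.41 log units; beyond the scatter), a large step in which 3-methoxyphenyl replaces 4-nitrophenyl, although that nitro-bearing group is not the 3-nitrophenyl of the new compound. The modest 7.0-fold higher number from compound 2 to compound 3 (0.85 log units; beyond the scatter) likewise ends at the 3-methoxyphenyl compound, while the modest 3.7-fold higher number from compound 1 to compound 2 (0.57 log units; beyond the scatter) compares nitro with chloro. Only part of the large step is expected to carry over, so a modest to large fall in the number is anticipated, with an expected 7.5-fold lower number from compound 3 to compound 4 (0.88 log units; beyond the scatter). Compound 4 is estimated at 1500 nM, with an expected range from 400 nM to 6000 nM.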

Compound 4, half-maximal inhibitory concentration: 2180 nM
Compound 4: the middle estimate sits 1.5-fold (0.16 log units) below what was measured; the measured number falls inside the stated range.
By their numbers in this assay, from the lowest: compound 1; then compounds 2 and 4 (each within the scatter of the next); then compound 3.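

In this assay the exchange of methoxy for nitro on this aromatic carbon, meta to a large group, now has a direct measure (a 5.2-fold lower number from compound 3 to compound 4 (0.71 log units; beyond the scatter)). The nitro group alone does not set the number, since 3-nitrophenyl in place of 4-nitrophenyl also gives a step beyond the scatter (a 5.0-fold higher number from compound 1 to compound 4 (0.70 log units; beyond the scatter)). The 3-nitrophenyl and 4-chlorophenyl compounds cannot be told apart in this read-out, as their step lies within the scatter (a 1.4-fold higher number from compound 2 to compound 4 (0.13 log units; within the scatter)).

Nothing among the data shown explains why these steps take the sizes they do. On these data alone, whether an amine or a nitrile on the same carbon would stay close to nitro or to methoxy remains open, as does the effect of a carboxylic acid there.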